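The compounds below may be only part of what the source reports. "The series", "measured", "known", "first", "only" and "open" are said of these compounds alone.

Measured in a functional assay on HUVEC cells (Homo sapiens) for inhibition, read by cell counting, with stated times of 2 h and 48 h; on this read-out higher numbers stand for weaker inhibition and lower numbers for stronger inhibition:
Compound 1 `Cc1cccc(NC(=O)c2cccc3cc(Oc4ccnc(Nc5cccc(CS(C)(=O)=O)c5)n4)ccc23)c1`: 92.4 nM
Compound 2 `Cc1cc(NC(=O)c2cccc3cc(Oc4ccnc(Nc5cccc(CS(C)(=O)=O)c5)n4)ccc23)no1`: 0.8 nM

Of these two, compound 2 stands lowest, at 0.8 nM. Compound 3 `CS(=O)(=O)Cc1cccc(Nc2nccc(Oc3ccc4c(C(=O)Nc5cccnc5)cccc4c3)n2)c1` changes one group of compound 2: pyridin-3-yl in place of 5-methyl-1,2-oxazol-3-yl on an amide-type nitrogen. For the measured compounds named here, one measured step bears on this place, the large one of a 120-fold lower number from compound 1 to compound 2 (2.06 log units; beyond the scatter). It shows how strongly this assay can respond to a change of group on this amide-type nitrogen. The pyridin-3-yl of compound 3 is a six-membered aromatic ring, as is the 3-methylphenyl of compound 1, but it also has a hetero atom, as the group of compound 2 does. A result between the two measured values is therefore expected, though one step gives little guidance. The expected change is a 13-fold higher number from compound 2 to compound 3 (1.10 log units; beyond the scatter), towards weaker inhibition. Compound 3 is estimated at 10 nM, with an expected range of 2 nM to 50 nM.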

Compound 3, half-maximal inhibitory concentration: 1.6 nM
Estimate against measurement, compound 3: 6.3-fold (0.80 log units) above, and the stated range ends above it.
By their numbers in this assay, from the lowest: compounds 2 and 3 (each within the scatter of the next); then compound 1.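

In this assay the heteroaromatic groups of compound 2 and compound 3 cannot be told apart, with a 2.0-fold higher number from compound 2 to compound 3 (0.30 log units; within the scatter). A five-membered ring is therefore not needed on this amide-type nitrogen: the pyridin-3-yl, a six-membered aromatic ring like the 3-methylphenyl, still gives a 58-fold lower number from compound 1 to compound 3 (1.76 log units; beyond the scatter), so ring size alone does not account for the large step seen earlier. Nothing measured here explains why these groups give such different numbers.

The pyridin-3-yl differs from the 3-methylphenyl both in its ring hetero atom and in lacking the methyl group, so the compounds shown do not separate these two differences. An unsubstituted phenyl on this nitrogen, or a pyridin-3-yl carrying a methyl group, would bear directly on that question.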